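A few compounds are considered here, and "the series" means these few. Any claim that something is new, unique, unknown or untested is made for them only; others in the source may bear on it.

Compound 1 `COc1cc(-c2ccnc3cc(-c4ccc(C(C)=O)cc4)nn23)cc(OC)c1OC`, compound 2 `COc1ccc(-c2cc3nccc(-c4cc(OC)c(OC)c(OC)c4)n3n2)cc1F` and compound 3 `COc1cc(-c2ccnc3cc(-c4c[nH]c5ccccc45)nn23)cc(OC)c1OC` share one core and differ only in the aryl group attached to it. In a functional assay on HCT-116 cells (Homo sapiens) for inhibition, read by CCK-8 assay, with a stated time of 48 h (on this read-out higher numbers stand for weaker inhibition and lower numbers for stronger inhibition), compound 1 gives 4390 nM, compound 2 gives 2840 nM, and compound 3 gives 35 nM. Compound 1 sits at the upper end of these three numbers: the step of a 1.5-fold lower number from compound 1 to compound 2 (0.19 log units; within the scatter) stays within the scatter, whereas the step of a 130-fold lower number from compound 1 to compound 3 (2.10 log units; beyond the scatter) is large and beyond it, as is the step of an 81-fold lower number from compound 2 to compound 3 (1.91 log units; beyond the scatter).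

Compound 4 `CCOC(=O)c1ccc(-c2cc3nccc(-c4cc(OC)c(OC)c(OC)c4)n3n2)cc1` has not yet been measured in this assay . It differs from compound 1 in one place: ethoxy in place of methyl on a carbonyl carbon. Where the measured steps exchange the whole aryl group on an aromatic carbon, this change keeps the aryl group and alters only the substituent on the carbonyl carbon. Among the measured compounds shown here, no measured pair shows an acetyl to ethoxycarbonyl exchange, so none of the three steps bears on it directly; the nearest comparison, the step from compound 1 to compound 2, shows that a small change on the aryl group moved the number only within the scatter. The same is therefore expected here: a step of a 1.1-fold lower number from compound 1 to compound 4 (0.04 log units; within the scatter) that does not rise beyond the scatter in either direction. Compound 4 is accordingly estimated at 4000 nM in this assay , with a range from 1300 nM to 12000 nM.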

Compound 4, half-maximal inhibitory concentration: > 10000 nM
Compound 4: a limit, no number; the forecaster's own chance of this, stated with the estimate: 10%; at least 2.5-fold (0.39 log units) between middle value and limit.
By their numbers in this assay, from the lowest: compound 3; then compounds 2 and 1 (each within the scatter of the next). At a limit, above all of these: compound 4.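

In this assay, compound 4 stands at a limit of the assay and not at a number: the limit of > 10000 nM in this assay, at which 1 of the 4 values shown sits.

Even so, the step can be read: ethoxy in place of methyl on a carbonyl carbon, with the rest of the structure unchanged, gives an at least 2.2-fold higher number from compound 1 to compound 4 (0.35 log units; beyond the scatter). Among the compounds shown here, the earlier steps all exchanged the whole aryl group, and the one that kept the number within the scatter, a 1.5-fold lower number from compound 1 to compound 2 (0.19 log units; within the scatter), might have suggested that modest changes on this aryl group matter little. This result shows instead that a change confined to the substituent on the carbonyl carbon can move the number beyond the scatter, towards weaker inhibition, although the limit leaves the full size of that step unknown.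

The compounds shown leave open whether a methyl ester, a primary amide or a carboxylic acid on this carbonyl carbon would stay close to compound 1 or move with compound 4. They also leave open whether a longer alkoxy chain would take the number further up, or whether an amine on the same carbon would bring it back down.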